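Lengthening a Saturated Chain While Half-life Holds Steady

The source may report more compounds than this note shows. Statements on the series, on what has been measured and on what is new or still open speak of the compounds shown alone.

Compound 1, `CCCCCCCNC(=O)Oc1ccc(Cl)cc1C(=O)Nc1cccc(Cl)c1`: 43 h
Compound 2, `CCCCCCCCNC(=O)Oc1ccc(Cl)cc1C(=O)Nc1cccc(Cl)c1`: 43 h
Compound 3, `CCCCCCCCCCNC(=O)Oc1ccc(Cl)cc1C(=O)Nc1ccc(Cl)c(Cl)c1`: 43 h

Of the compounds shown here, three have so far been measured in an ADME assay for metabolic stability, read by HPLC, at pH 7.4; on this read-out lower numbers stand for a shorter-lived compound and higher numbers for a longer-lived compound. Compound 1 gives 43 h. Compound 2 differs from compound 1 by methyl in place of hydrogen on a saturated chain carbon, seven bonds along the chain from an amide-type nitrogen, and in this assay compound 2 gives 43 h; the step of no change at the digits printed from compound 1 to compound 2 (within the scatter) therefore sits within the usual scatter of this kind of measurement. Compound 3 carries a different core; the difference between the two cores is not broken down here. In this assay compound 3 gives 43 h, which is level with compounds 1 and 2 within the scatter.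

Compound 4, `CCCCCCCCCCCNC(=O)Oc1ccc(Cl)cc1C(=O)Nc1ccc(Cl)c(Cl)c1`, has not yet been measured. It differs from compound 3 by methyl in place of hydrogen on a saturated chain carbon, ten or more bonds along the chain from an amide-type nitrogen. This is the same kind of change as that from compound 1 to compound 2, though not the same: the two entering methyl groups stand at different distances along the chain from an amide-type nitrogen, as the two differences just given show. Because no change at the digits printed from compound 1 to compound 2 (within the scatter) showed no change in half-life when the chain was lengthened by one carbon, a similarly flat step no change at the digits printed from compound 3 to compound 4 (within the scatter) is expected here. Compound 4 is therefore estimated to give about 43 h in this assay, with an expected range from 25 h to 75 h. This expectation rests only on three compounds and one measured step, so it remains tentative.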

Compound 4, half-life: 43 h
Estimate against measurement, compound 4: no gap at the digits printed, within the range that was stated.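

In this assay, putting methyl in place of hydrogen on a saturated chain carbon, ten or more bonds along the chain from an amide-type nitrogen, gives no change at the digits printed from compound 3 to compound 4 (within the scatter). Set beside the earlier step, which places the entering methyl at a different distance along the chain on the other core, the two results agree: the same change on two cores in this assay, no change at the digits printed (within the scatter) from compound 1 to compound 2 and no change at the digits printed (within the scatter) from compound 3 to compound 4, 1.0-fold (0.00 log units) apart, within the scatter of two such steps

So, for these two cores and these two chain positions, this one-carbon change carries over with no difference that can be told from the scatter, but this is a narrow result: two flat steps show neither that the same would hold on a third core nor that it would hold at every chain length, and they say nothing of why the half-life is level.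

The compounds shown leave open whether this assay would still read level for a shorter chain such as butyl, a longer chain than that of compound 4, or a chain carrying an amine or a carboxylic acid. They also leave open whether a core with a fluorine or a methoxy group in place of a chlorine would give the same flat step.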